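The compounds below may be only part of what the source reports. "The series", "measured", "known", "first", "only" and "open" are said of these compounds alone.

Working notes on the series. In a functional assay on FL5.12 cells (Mus musculus), read by flow cytometry, with a stated time of 3 h, tested at 2.5 uM (on this read-out higher numbers stand for a stronger effect at the one concentration tested and lower numbers for a weaker effect), compound 1 `CCCCCCCCc1ccc(C(=O)C[C@@H]2C[C@@H](O)CN2)cc1` gives 22%. Going by the values given here, compound 2 `CCCCCCCCc1ccc(C(=O)CC[C@H]2C[C@H](CO)CN2)cc1` gives 8% in this assay, the lower of the two numbers measured so far; the only neighbour is compound 1, and the change is a number 14 percentage points lower from compound 1 to compound 2 (beyond the scatter), a single step in which a group of 8 heavy atoms replaces a group of 6 heavy atoms on a saturated chain carbon bound to a carbonyl carbon.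

Compound 3 `CCCCCCCCc1ccc(C(=O)CC[C@@H]2C[C@@H](O)CN2)cc1` has not been measured. It differs from compound 2 in one place: a group of 6 heavy atoms (4 carbon, 1 nitrogen, 1 oxygen; one five-membered non-aromatic ring with 1 hetero atom) in place of a group of 7 heavy atoms (5 carbon, 1 nitrogen, 1 oxygen; one five-membered non-aromatic ring with 1 hetero atom), on a saturated chain carbon, two bonds along the chain from a carbonyl carbon. The 4-hydroxypyrrolidin-2-yl group that enters is the same group carried by compound 1, while the place of attachment, two bonds along the chain from a carbonyl carbon, is that of compound 2. Among the compounds with values here, the one measured step thus bears on compound 3 only in part; it points towards a number above compound 2 and no higher than compound 1. The step from compound 2 to compound 3 is expected to be a number 6 percentage points higher from compound 2 to compound 3 (within the scatter). Compound 3 is estimated at 14%, in the range 4% to 26%.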

Compound 3, a percentage reported as activity, at one concentration (the size of the read-out at that concentration, not a potency): 15%
The estimate for compound 3 lay 1 percentage points below the measured number, and the stated range covers the measured number.
By their numbers in this assay, from the lowest: compounds 2, 3 and 1 (each within the scatter of the next, the first and the last beyond it).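

In this assay the change of (4-hydroxypyrrolidin-2-yl)methyl to 4-hydroxypyrrolidin-2-yl on a saturated chain carbon bound to a carbonyl carbon is now read apart from the rest, and the result is a number 7 percentage points lower from compound 1 to compound 3 (within the scatter) for this series. The other change, which puts 4-hydroxypyrrolidin-2-yl in place of the unnamed group of 7 heavy atoms on a saturated chain carbon, two bonds along the chain from a carbonyl carbon, gives a number 7 percentage points higher from compound 2 to compound 3 (within the scatter) and so also stays inside the scatter, which means that the gap beyond the scatter seen earlier between compound 1 and compound 2 is not reproduced by either single change taken alone. No measurement at hand bears on the reason for these numbers.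

With one concentration per compound, these numbers give the size of the read-out and not a potency. The compounds shown leave open how the read-out responds to a longer chain on the saturated chain carbon, or to an amine or a carboxylic acid in place of the hydroxy group of 4-hydroxypyrrolidin-2-yl.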